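Fluoro in place of bromo on compound 3

A few compounds are considered here, and "the series" means these few. Any claim that something is new, unique, unknown or untested is made for them only; others in the source may bear on it.

Compound 1 `COc1ccccc1NC(=O)SC[C@H](NC(C)=O)C(=O)O` reaches > 200000 nM in a functional assay on UACC-62 cells (Homo sapiens) for cytotoxicity, read by MTT assay, with a stated time of 6 days (on this read-out lower numbers stand for stronger inhibition and higher numbers for weaker inhibition), which is a limit and not a number. In this assay compound 2 `COc1ccc(NC(=O)SC[C@H](NC(C)=O)C(=O)O)cc1` gives 75200 nM, and compound 3 `CC(=O)N[C@@H](CSC(=O)Nc1ccc(Br)cc1)C(=O)O` gives 320 nM, the lower of the two numbers in this set. Compound 4 `CC(=O)N[C@@H](CSC(=O)Nc1ccc(F)cc1)C(=O)O` differs from compound 3 at one place: fluoro in place of bromo on an aromatic carbon, para to a large group (fluoro in place of bromo on an aromatic carbon). One measured step changes the group at this place: a 240-fold lower number from compound 2 to compound 3 (2.37 log units; beyond the scatter), a large step with bromo in place of methoxy. Going by the values given here, no measured compound carries fluoro, so the size of the next step is uncertain. Among the compounds with values here, with a 240-fold lower number from compound 2 to compound 3 (2.37 log units; beyond the scatter) as the only guide, a higher number is expected on losing bromo, though a smaller move than that one. A step of a 13-fold higher number from compound 3 to compound 4 (1.10 log units; beyond the scatter) is therefore expected in this assay. For compound 4 the estimated value is 4000 nM, with an expected range from 600 nM to 30000 nM.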

Compound 4, half-maximal inhibitory concentration in the UACC-62 assay: 36 nM
Estimate against measurement, compound 4: 110-fold (2.05 log units) above; the measured number lies below the stated range.
By their numbers in the UACC-62 assay, from the lowest: compound 4; then compound 3; then compound 2. At a limit, above all of these: compound 1.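

In the UACC-62 assay there is an 8.9-fold lower number from compound 3 to compound 4 (0.95 log units; beyond the scatter), so at the aromatic carbon para to a large group, bromo is not required for a low number: compound 4 gives 36 nM. Fluoro also goes well beyond the methoxy result at this place, with a 2100-fold lower number from compound 2 to compound 4 (3.32 log units; beyond the scatter) as the widest step among those shown. In a physicochemical assay for solubility, in phosphate buffer, at pH 7.4 (on this read-out higher numbers stand for higher solubility and lower numbers for lower solubility), compound 3 gives 24 ug/mL and compound 4 gives 26 ug/mL. In the physicochemical assay the same exchange of halogens gives a 1.1-fold higher number from compound 3 to compound 4 (0.03 log units; within the scatter), so that read-out does not separate the two.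

Nothing measured here gives a cause for the step from bromo to fluoro. As far as these compounds go, it remains open whether chloro, trifluoromethyl or a nitrile at this place would give numbers like those of compound 4 in the UACC-62 assay, and whether the low numbers survive exchange of the carboxylic acid for an amide.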